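This account rests on a few compounds, and the source may have more. Where it says the series, first, only, none or still open, it means among the compounds named here.

Of the compounds shown here, three that share one core have so far been tested in an assay on isolated protein for inhibition of Rho-associated protein kinase 2 (Homo sapiens), read by scintillation counting, radiometric assay and 33P incorporation, with a stated time of 40 min, in the presence of a further agent that is not named here; on this read-out lower numbers stand for stronger inhibition and higher numbers for weaker inhibition. Compound 1 `Cc1ccc(C(=O)Nc2cccc(NC(=O)COc3ccc4c(=O)ccoc4c3)c2)cc1` gives 22 nM, compound 2 `O=C(COc1ccc2c(=O)ccoc2c1)Nc1cccc(NC(=O)c2ccc(OC(F)(F)F)cc2)c1` gives 77 nM, and compound 3 `COC(=O)c1ccc(C(=O)Nc2cccc(NC(=O)COc3ccc4c(=O)ccoc4c3)c2)cc1` gives 29 nM. Compound 3 therefore stands second highest of the three numbers: its distance from compound 1 is a 1.3-fold higher number from compound 1 to compound 3 (0.12 log units; within the scatter), while its distance from compound 2 is a 2.7-fold lower number from compound 2 to compound 3 (0.42 log units; beyond the scatter). All three compounds differ only in the group that sits on the carbonyl carbon. Compound 4 `O=C(COc1ccc2c(=O)ccoc2c1)Nc1cccc(NC(=O)c2cnc(C(F)(F)F)s2)c1` has not yet been measured; here the whole group is exchanged: 2-(trifluoromethyl)-1,3-thiazol-5-yl in place of 4-(methoxycarbonyl)phenyl on a carbonyl carbon. The measured steps all concern this same position, and the largest of them, a 3.5-fold higher number from compound 1 to compound 2 (0.54 log units; beyond the scatter), was modest. Exchanging the complete ring is a bigger change than any of those, so a modest move towards higher numbers in this assay seems the likeliest outcome, though a step within the scatter cannot be ruled out. For compound 4 the expected step is a 2.1-fold higher number from compound 3 to compound 4 (0.32 log units; beyond the scatter). The estimate for compound 4 is 60 nM, within a range from 20 nM to 200 nM.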

Compound 4, half-maximal inhibitory concentration: 10 nM
Estimate against measurement, compound 4: 6.0-fold (0.78 log units) above; the whole stated range lies above it.
By their numbers in this assay, from the lowest: compound 4; then compounds 1 and 3 (each within the scatter of the next); then compound 2.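

Compound 4 is the only one of the four in which the ring itself changes, and in this assay it has the lowest number of the set (a 2.2-fold lower number from compound 1 to compound 4 (0.34 log units; beyond the scatter); a 2.9-fold lower number from compound 3 to compound 4 (0.46 log units; beyond the scatter); a 7.7-fold lower number from compound 2 to compound 4 (0.89 log units; beyond the scatter)). On a carbonyl carbon, then, a five-membered aromatic ring with 2 hetero atoms can replace a six-membered aromatic ring of carbon only, and inhibition becomes stronger rather than weaker. Nothing measured here explains this gain.

The compounds shown do not separate the effect of the new ring from that of the trifluoromethyl group it carries. A thiazole ring bearing an amine or a methyl group instead, or a 4-(trifluoromethyl)phenyl group, would tell the two apart.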